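Swapping the triazole substituent: from a fused lactam to cyanobenzyl

A few compounds are considered here, and "the series" means these few. Any claim that something is new, unique, unknown or untested is made for them only; others in the source may bear on it.

Compound 1: `COC1=C(C)C(=O)C(CCCCCCCCCCn2cc(C[C@H](O)COCCOC[C@@H](O)Cc3ccc(-c4ccccc4)cc3)nn2)=C(C)C1=O`, 4000 nM
Compound 2: `O=C1COc2ccc(-n3cc(C[C@H](O)COCCOC[C@@H](O)Cc4ccc(-c5ccccc5)cc4)nn3)cc2N1`, 42500 nM

Both compounds were tested in a functional assay on HCT-116 cells (Homo sapiens) for inhibition, read by MTT assay, with a stated time of 72 h; a higher number here means a weaker inhibitor of growth, a lower number a stronger inhibitor of growth. Compound 2 gives the higher of the two numbers, 42500 nM, so it is the weaker of the pair; compound 1 gives 4000 nM, a gap that lies beyond the usual scatter. Within the data shown here, the two compounds differ in several places at once, so no single step between them is defined, and only their two values can be compared.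

Compound 3, `N#Cc1ccc(Cn2cc(C[C@H](O)COCCOC[C@@H](O)Cc3ccc(-c4ccccc4)cc3)nn2)cc1`, keeps the shared core and changes one place: a group of 9 heavy atoms (8 carbon, 1 nitrogen; one six-membered aromatic ring of carbon only) in place of a group of 11 heavy atoms (8 carbon, 1 nitrogen, 2 oxygen; one six-membered non-aromatic ring with 2 hetero atoms, one six-membered aromatic ring of carbon only), on an aromatic nitrogen. Among the measured compounds shown here, nothing measured so far isolates what this swap on the aromatic nitrogen does. With only two data points, and the values of compound 2 and compound 1 as the available anchors, the expectation for the step of a 2.1-fold lower number from compound 2 to compound 3 (0.33 log units; beyond the scatter) is a modest move toward a lower number, at most just beyond the scatter, and possibly none at all. On that basis compound 3 is estimated to give 20000 nM in this assay, with a range from 6000 nM to 60000 nM.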

Compound 3, concentration for 50% growth inhibition: 8800 nM
Beside the measured number, compound 3's estimate is 2.3-fold (0.36 log units) above it; measured number inside the range.
By their numbers in this assay, from the lowest: compound 1; then compound 3; then compound 2.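

The group on the aromatic nitrogen clearly affects growth inhibition: in this assay, replacing the two-ring group with 4-cyanobenzyl gives a 4.8-fold lower number from compound 2 to compound 3 (0.68 log units; beyond the scatter), a modest step. The change removes the six-membered non-aromatic ring and the hydrogen-bond donor and adds a nitrile, yet the number falls rather than rises, so neither the ring nor the donor is required for this level of growth inhibition in this pair. No measurement on hand explains why the number moves.

The two groups differ in their rings, their donors and acceptors, and the nitrile all at once. This one step cannot show which difference matters, or whether the benzyl carbon joining the aromatic ring to the aromatic nitrogen contributes. A plain benzyl group would test the nitrile on its own, while a 4-aminobenzyl group or a benzyl group carrying a carboxylic acid would show whether the same position accepts a different substituent on that aromatic ring.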